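This account rests on a few compounds, and the source may have more. Where it says the series, first, only, none or still open, it means among the compounds named here.

Compound 1 `Cc1cccc(Cl)c1CN1CCc2cc(-c3c(C)nc(C)c([C@H](OC(C)(C)C)C(=O)O)c3N3CCC(C)(C)CC3)ccc2C1` was measured in an ADME assay on the whole organism (Rattus norvegicus, strain Sprague-Dawley) for pharmacokinetics, read by LC-MS, at a dose of 1 mg/kg by the intravenous route (on this read-out higher numbers stand for fast clearance and lower numbers for slow clearance), where compound 1 gives 3.5 mL/min/kg, the lowest of the three numbers in hand. Compound 2 `Cc1nc(C)c([C@H](OC(C)(C)C)C(=O)O)c(N2CCC(C)(C)CC2)c1-c1ccc2c(c1)CCN(Cc1cccc(F)c1F)C2` gives 8.1 mL/min/kg, and compound 3 `Cc1nc(C)c([C@H](OC(C)(C)C)C(=O)O)c(N2CCC(C)(C)CC2)c1-c1ccc2c(c1)CCN(c1ncnc3c1cnn3C)C2` gives 3.6 mL/min/kg. The steps among these three show a 2.3-fold higher number from compound 1 to compound 2 (0.36 log units; beyond the scatter), a 1.0-fold higher number from compound 1 to compound 3 (0.01 log units; within the scatter) and a 2.3-fold lower number from compound 2 to compound 3 (0.35 log units; beyond the scatter); each of them changes the group on an amine nitrogen in a ring, not the aromatic carbon changed here. Compound 4 `Cc1cccc(Cl)c1CN1CCc2cc(-c3cnc(C)c([C@H](OC(C)(C)C)C(=O)O)c3N3CCC(C)(C)CC3)ccc2C1` differs from compound 1 as follows: hydrogen in place of methyl on an aromatic carbon. Within the data shown here, no measured step in this set touches that aromatic carbon, so there is no direct precedent for the change; the only guidance is that every change measured so far moved clearance by a modest amount at most. The expectation is therefore a step of about a 1.1-fold higher number from compound 1 to compound 4 (0.06 log units; within the scatter), which is none beyond the scatter. Compound 4 is expected to give 4 mL/min/kg in this assay, with a range from 2 mL/min/kg to 8 mL/min/kg.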

Compound 4, clearance: 3.8 mL/min/kg
Estimate against measurement, compound 4: 1.1-fold (0.02 log units) above; the range from low to high includes it.
By their numbers in this assay, from the lowest: compounds 1, 3 and 4 (each within the scatter of the next); then compound 2.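

In this assay, among these compounds, hydrogen in place of methyl on the aromatic carbon next to the ring nitrogen gives a 1.1-fold higher number from compound 1 to compound 4 (0.04 log units; within the scatter) and so stays within the scatter, the first reading at this position. Among the compounds shown here, every earlier step changed the group on an amine nitrogen in a ring, so this is the first sign that clearance can also hold when the change lies on an aromatic carbon. Nothing in hand explains why this methyl group can leave without a change beyond the scatter.

The compounds shown leave open whether hydrogen would behave the same way with the 2,3-difluorophenyl group of compound 2 or the group on the amine nitrogen of compound 3. They also leave open what a larger or different group at this aromatic carbon, such as ethyl, methoxy, trifluoromethyl or an amine, would do to clearance.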